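The compounds below may be only part of what the source reports. "The series", "measured", "known", "first", "only" and "open" are said of these compounds alone.

Measured compounds in an assay on CHO cells for displacement of a labelled ligand from 5-hydroxytryptamine receptor 1B (Homo sapiens); a higher number here means a weaker inhibitor, a lower number a stronger inhibitor:
compound 1 `O[C@H]1Cc2ccccc2C1NC1CCN(CCCc2c[nH]c3ccc(-n4cnnc4)cc23)CC1` gives 300 nM;
compound 2 `O[C@@H]1Cc2ccccc2[C@H]1NC1CCN(CCCc2c[nH]c3ccc(-n4cnnc4)cc23)CC1` gives 210 nM;
compound 3 `c1ccc2c(c1)CCC2NC1CCN(CCCc2c[nH]c3ccc(-n4cnnc4)cc23)CC1` gives 280 nM.

Among these three numbers compound 3 holds the second highest; the nearest step to it is a 1.1-fold lower number from compound 1 to compound 3 (0.03 log units; within the scatter) and the furthest is a 1.3-fold higher number from compound 2 to compound 3 (0.12 log units; within the scatter), so all three sit together within the scatter. Compound 4 `CC(C)=CCN(C)C1CCN(CCCc2c[nH]c3ccc(-n4cnnc4)cc23)CC1` carries methyl(3-methylbut-2-en-1-yl)amino in place of (2,3-dihydro-1H-inden-1-yl)amino on a saturated ring carbon. Within the data shown here, the measured steps that touch this part of the molecule, a 1.1-fold lower number from compound 1 to compound 3 (0.03 log units; within the scatter) and a 1.3-fold higher number from compound 2 to compound 3 (0.12 log units; within the scatter), were both small, but neither removes the two rings or caps the nitrogen with a methyl, so they offer no direct precedent for a change of this size. A modest shift toward a higher number is therefore expected, a 1.8-fold higher number from compound 3 to compound 4 (0.25 log units; within the scatter), with wide uncertainty. Compound 4 is estimated at 500 nM, in the range 150 nM to 1700 nM.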

Compound 4, half-maximal inhibitory concentration: 41 nM
Compound 4: middle estimate off by 12-fold (1.09 log units), on the high side; measured number below the stated range.
By their numbers in this assay, from the lowest: compound 4; then compounds 2, 3 and 1 (each within the scatter of the next).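

In this assay, methyl(3-methylbut-2-en-1-yl)amino in place of (2,3-dihydro-1H-inden-1-yl)amino gives a 6.8-fold lower number from compound 3 to compound 4 (0.83 log units; beyond the scatter), and the comparisons with the hydroxy-bearing amines agree: a 5.1-fold lower number from compound 2 to compound 4 (0.71 log units; beyond the scatter) and a 7.3-fold lower number from compound 1 to compound 4 (0.86 log units; beyond the scatter). Among these compounds, this position, which looked flat across the earlier compounds, therefore responds to the amine substituent, and a lower number does not require the two rings. Nothing given here accounts for the gain.

The change removes the rings, adds a methyl on nitrogen and brings in a double bond all at once, so the part responsible remains unresolved. As far as these compounds go, whether a saturated 3-methylbutyl chain or a methyl on the nitrogen of (2,3-dihydro-1H-inden-1-yl)amino would do the same stays open.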